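Compound 1 to compound 3: one more aromatic methyl

A few compounds are considered here, and "the series" means these few. Any claim that something is new, unique, unknown or untested is made for them only; others in the source may bear on it.

Compound 1 `COc1ccc(C2(O)/C(=C/c3ccccc3)CCCC2CN(C)c2ccccc2)cc1` gives 75.7% in a functional assay on the whole organism (strain Kunming) for inhibition, with Mus musculus as the target, in the writhing test, with stated times of 1 h and 15 min, at a dose of 200 mg/kg by the oral route (on this read-out lower numbers stand for less inhibition and higher numbers for more inhibition at the one dose given (going by the name of the read-out)), and stands lowest of the two numbers measured, with compound 2 `COc1ccc(C2(O)/C(=C/c3ccccc3)CCCC2CN(C)c2ccc(C)cc2)cc1` nearest at 78.7%. Among the compounds with values here, the only measured step, a number 3 percentage points higher from compound 1 to compound 2 (within the scatter), also put methyl in place of hydrogen on an aromatic carbon and stayed within the scatter. Compound 3 `COc1ccc(C2(O)/C(=C/c3ccc(C)cc3)CCCC2CN(C)c2ccccc2)cc1` differs from compound 1 by methyl in place of hydrogen on an aromatic carbon. Within the data shown here, that single step is the sole guide, so the expected change is a number 1.3 percentage points higher from compound 1 to compound 3 (within the scatter), nothing beyond the scatter. Compound 3 is therefore estimated at 77%, with a range of 68% to 86%.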

Compound 3, a percentage reported as inhibition, in the whole organism at one dose (the size of the read-out at that dose, not a potency): 72.1%
For compound 3 the middle estimate is 4.9 percentage points above the measured one, within the range that was stated.
By their numbers in this assay, from the lowest: compounds 3, 1 and 2 (each within the scatter of the next).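

In this assay, the change from phenyl to 4-methylphenyl at this position gives a number 3.6 percentage points lower from compound 1 to compound 3 (within the scatter). A methyl para to a large group is therefore accommodated on this second aromatic ring as well, with no shift beyond the scatter at either site so far. No evidence here bears on this result.

As far as these compounds go, it remains open whether a different group at this position, such as an amine, a carboxylic acid or a longer chain, would move the number beyond the scatter. From the compounds shown here alone, the response at other doses also remains open.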